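A few compounds are considered here, and "the series" means these few. Any claim that something is new, unique, unknown or untested is made for them only; others in the source may bear on it.

Measured so far in a functional assay on HeLa cells (Homo sapiens) for inhibition, read by sulforhodamine B assay (on this read-out higher numbers stand for weaker inhibition and lower numbers for stronger inhibition), are two compounds:
Compound 1 `O=C1C=C(NCc2ccccc2)C(=O)c2c1nc1n2[C@H]2OC[C@@H](O)[C@H]2OC1` gives > 8000 nM as a limit
Compound 2 `CCOc1ccc(NC2=CC(=O)c3nc4n(c3C2=O)[C@H]2OC[C@@H](O)[C@H]2OC4)cc1` gives 3110 nM as a number

Among the measured compounds shown here, compound 2 holds the only actual number, and the other entry is a limit. For the measured compounds named here, the one measured step is an at least 2.5-fold lower number from compound 1 to compound 2 (0.41 log units; beyond the scatter) and it brings 4-ethoxyphenyl in place of benzyl on an amine nitrogen. That step leaves the groups carried on the aromatic ring untouched, so it bears only loosely on the next change.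

Compound 3 `Cc1ccc(NC2=CC(=O)c3nc4n(c3C2=O)[C@H]2OC[C@@H](O)[C@H]2OC4)cc1C` is not yet measured. Its difference is 3,4-dimethylphenyl in place of 4-ethoxyphenyl on an amine nitrogen with 3,4-dimethylphenyl in place of 4-ethoxyphenyl on an amine nitrogen. Going by the values given here, no measured step shows an exchange of this kind. With compound 2 at 3110 nM as the anchor, no step beyond the scatter is expected in this assay for this exchange. The expected step is a 1.0-fold lower number from compound 2 to compound 3 (0.02 log units; within the scatter) as an estimate only. For compound 3 the estimated value is 3000 nM with an expected range from 1000 nM to 8000 nM for this read-out.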

Compound 3, half-maximal inhibitory concentration: 2690 nM
Estimate against measurement, compound 3: 1.1-fold (0.05 log units) above, and the stated range covers the measured number.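

In this assay, a 1.2-fold lower number from compound 2 to compound 3 (0.06 log units; within the scatter), so at this position on the amine nitrogen the exchange gives no readable change, even though the oxygen and the hydrogen-bond acceptor of 4-ethoxyphenyl leave with it and the entering 3,4-dimethylphenyl has neither. The second comparison, an at least 2.9-fold lower number from compound 1 to compound 3 (0.47 log units; beyond the scatter), puts a second group beside 4-ethoxyphenyl that gives a measured number where benzyl does not, and compounds 2 and 3 are the only support for this reading, with no listed compound going against it. Compound 1 stands at a limit and not at a number, which leaves the true size of both steps from it unread: the limit of > 8000 nM in this assay, at which 1 of the 3 values shown sits.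

The compounds shown leave open whether an unsubstituted phenyl, a chlorophenyl or a phenyl carrying a carboxylic acid or an amine would stay level with compounds 2 and 3 or move beyond the scatter. They also leave open whether the 3,4-dimethyl pattern or the 4-ethoxy group contributes on its own, since a single methyl or a longer alkoxy chain does not appear among them.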